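Substituent exchange on the fused ring: compound 4

The source may report more compounds than this note shows. Statements on the series, on what has been measured and on what is new or still open speak of the compounds shown alone.

Compound 1 `CCC(CC)(CC(=O)Nc1cccc(OCc2ccc3ccccc3n2)c1)C(=O)O` gives 0.9 nM in a functional assay on ileum (Cavia porcellus) for antagonist activity at cysteinyl leukotriene receptor (Homo sapiens); on this read-out lower numbers stand for stronger inhibition and higher numbers for weaker inhibition. Compound 2 `CCC(CC)(CC(=O)Nc1cccc(OCc2ccc3ccc(C)cc3n2)c1)C(=O)O` carries a methyl on an aromatic carbon of the fused ring and gives 11 nM in this assay; compound 3 `CCC(CC)(CC(=O)Nc1cccc(OCc2ccc3ccc(OC(F)(F)F)cc3n2)c1)C(=O)O` carries a trifluoromethoxy on an aromatic carbon of the fused ring and gives 9 nM. Compound 3 thus stands second highest of the three numbers, close to compound 2 and far from compound 1: a 10-fold higher number from compound 1 to compound 3 (1.00 log units; beyond the scatter), while a 1.2-fold lower number from compound 2 to compound 3 (0.09 log units; within the scatter).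

Compound 4 `CCC(CC)(CC(=O)Nc1cccc(OCc2ccc3ccc(C(C)=O)cc3n2)c1)C(=O)O` differs from compound 3 by acetyl in place of trifluoromethoxy on an aromatic carbon. Among the compounds with values here, three measured steps bear on this change. The steps of a 12-fold higher number from compound 1 to compound 2 (1.09 log units; beyond the scatter) and a 10-fold higher number from compound 1 to compound 3 (1.00 log units; beyond the scatter) show that either substituent on that aromatic carbon raised the number well beyond the scatter. The step of a 1.2-fold lower number from compound 2 to compound 3 (0.09 log units; within the scatter) shows that exchanging one such substituent for another left the number within the scatter. Acetyl is a third substituent on the same aromatic carbon, so compound 4 is expected to stay near compound 3 rather than return toward compound 1. The expected step is a 1.1-fold higher number from compound 3 to compound 4 (0.05 log units; within the scatter), within the scatter. The estimate for compound 4 is 10 nM, with a range from 3 nM to 40 nM.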

Compound 4, half-maximal inhibitory concentration: 2500 nM
The estimate for compound 4 lay 250-fold (2.40 log units) below the measured number; measured number above the stated range.
By their numbers in this assay, from the lowest: compound 1; then compounds 3 and 2 (each within the scatter of the next); then compound 4.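

Within the data shown here, this aromatic carbon does not treat all substituents alike: in this assay acetyl gives a 280-fold higher number from compound 3 to compound 4 (2.44 log units; beyond the scatter) and a 230-fold higher number from compound 2 to compound 4 (2.36 log units; beyond the scatter) while methyl and trifluoromethoxy lie within the scatter of each other, so the earlier pair gave no sign of a step of this size. Against hydrogen the change is a 2800-fold higher number from compound 1 to compound 4 (3.44 log units; beyond the scatter) and it outstrips the steps to the other two substituents, and the heavy-atom count does not track it, since acetyl has fewer heavy atoms than trifluoromethoxy, the same hydrogen-bond acceptor count, and a double bond outside aromatic rings that trifluoromethoxy lacks. Nothing at hand accounts for the difference between acetyl and the other two substituents.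

The compounds shown leave open whether the step belongs to the carbonyl of acetyl or to the acetyl group as a whole, and a 1-hydroxyethyl group, a nitrile, an amine or a carboxylic acid on the same aromatic carbon would help to separate these readings. They also leave open whether acetyl at another carbon of the fused ring would give a step of similar size.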